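A few compounds are considered here, and "the series" means these few. Any claim that something is new, unique, unknown or untested is made for them only; others in the source may bear on it.

Three related compounds have entries in an ADME assay on CHO cells (Cricetulus griseus) for cytotoxicity, read by LDH release; a lower number here means a stronger inhibitor, a higher number a weaker inhibitor. Compound 1 `CC(Oc1ccc(Cl)cc1Cl)C(=O)NCc1ccccc1F` gives 47000 nM, the higher of the two numbers available. Compound 3 `CC(Oc1ccc(Cl)cc1Cl)C(=O)NCc1cc2ccccc2[nH]1` gives 12000 nM, a lower number by a gap beyond the usual scatter. For compound 2 `COc1ccccc1CNC(=O)C(C)Oc1ccc(Cl)cc1Cl` the entry reads "not determined" (no result reported), so it offers no comparison.

Still unmeasured is compound 4 `CC(Oc1ccc(Cl)cc1Cl)C(=O)NCc1ccc(F)nc1`, which carries 6-fluoropyridin-3-yl in place of 2-fluorophenyl on a saturated chain carbon bound to an amide-type nitrogen. Among the compounds with values here, no measured pair here shows this swap, so the data give no direct guide to its effect. Within the data shown here, the only starting point is compound 1 at 47000 nM, and no step beyond the scatter is expected in this assay, in either direction. The expected change is small: a 1.0-fold lower number from compound 1 to compound 4 (0.02 log units; within the scatter). The number estimated for compound 4 is 45000 nM, with an expected range from 18000 nM to 100000 nM.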

Compound 4, half-maximal inhibitory concentration: > 100000 nM
Compound 4 gave a limit, no number; the forecaster's own chance of this, stated with the estimate: 25%; middle value at least 2.2-fold (0.34 log units) from the limit.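

Swapping 2-fluorophenyl for 6-fluoropyridin-3-yl on a saturated chain carbon bound to an amide-type nitrogen is not a silent change in this assay: it gives an at least 2.1-fold higher number from compound 1 to compound 4 (0.32 log units; beyond the scatter). Compound 4 gives > 100000 nM, which is a limit and not a number. This single step ties a ring with one hetero atom and one hydrogen-bond acceptor to a higher number at this position, but how much higher stays unknown because only a limit is available: the limit of > 100000 nM in this assay, at which 1 of the 4 values shown sits.

These compounds cannot separate the effect of the ring nitrogen from that of the different fluorine placement, since the two groups differ in both. Going by these compounds, it also remains open how a plain phenyl ring, or a ring carrying an amine or a carboxylic acid, would read at this position.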